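A few compounds are considered here, and "the series" means these few. Any claim that something is new, unique, unknown or untested is made for them only; others in the source may bear on it.

In a physicochemical assay for solubility, in phosphate buffer, with a stated time of 18 h (on this read-out lower numbers stand for lower solubility and higher numbers for higher solubility), compound 1 `CCCCc1nc(C(C)(C)C)nc2nc(N)c(C#N)c(N)c12` gives 6000 nM and compound 3 `CC(C)(C)c1nc(-c2ccccc2)c2c(N)c(C#N)c(N)nc2n1` gives 4000 nM, two values within the scatter of each other. Compound 2 `CC(C)(C)c1nc(-c2nccs2)c2c(N)c(C#N)c(N)nc2n1` gives no number, only a limit of the assay, < 1500 nM. Compound 3 therefore stands level with compound 1, and its only clear separation is from that limit.

Compound 4 `CC(C)(C)c1nc(-c2ncn[nH]2)c2c(N)c(C#N)c(N)nc2n1` has 1H-1,2,4-triazol-5-yl in place of phenyl on an aromatic carbon, (1H-1,2,4-triazol-5-yl in place of phenyl on an aromatic carbon). For the measured compounds named here, two measured steps bear on this position. The first, a 1.5-fold lower number from compound 1 to compound 3 (0.18 log units; within the scatter), shows that phenyl and butyl are not told apart here. The second, an at least 2.6-fold higher number from compound 2 to compound 3 (0.42 log units; beyond the scatter), exchanges 1,3-thiazol-2-yl for phenyl, and read in reverse it suggests that a five-membered aromatic ring could bring a lower number. However, 1,3-thiazol-2-yl is not the group entering here, so only part of that step is carried over.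

The expected change is small and slightly downward, a 1.3-fold lower number from compound 3 to compound 4 (0.12 log units; within the scatter), an estimate within the scatter. Compound 4 is expected at 3000 nM, with an estimated range of 1000 nM to 9000 nM.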

Compound 4, solubility: 64500 nM
Beside the measured number, compound 4's estimate is 22-fold (1.33 log units) below it; measured number outside the range, above it.
By their numbers in this assay, from the lowest: compounds 3 and 1 (each within the scatter of the next); then compound 4. At a limit, below all of these: compound 2.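

In this assay the change to 1H-1,2,4-triazol-5-yl gives a 16-fold higher number from compound 3 to compound 4 (1.21 log units; beyond the scatter) and, measured against butyl, an 11-fold higher number from compound 1 to compound 4 (1.03 log units; beyond the scatter) on this same aromatic carbon; this position can therefore separate groups by a large step, which phenyl and butyl, within the scatter of each other, did not show. The two five-membered aromatic rings also part widely, with an at least 43-fold higher number from compound 2 to compound 4 (1.63 log units; beyond the scatter) in the step from 1,3-thiazol-2-yl, so a five-membered aromatic ring as such does not bring a lower number here. That step only sets a bound, and compound 2 stands at a limit of the assay: the limit of < 1500 nM in this assay, at which 1 of the 4 values shown sits.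

The compounds shown do not tell whether the step goes with the hydrogen-bond donor of the entering ring or with its nitrogen atoms. From the compounds shown here alone, how an imidazolyl group or a methyl-substituted triazolyl group would read on this carbon stays open.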